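Removing the tert-butyl ether from a serine-derived urea side chain

This account rests on a few compounds, and the source may have more. Where it says the series, first, only, none or still open, it means among the compounds named here.

Measured compounds:
- compound 1, `CC[C@H](C)[C@H](NC(=O)N1CCC2(CC1)C(=O)N(C)C2c1ccc(Cl)cc1)C(=O)OC`: 800 nM
- compound 2, `CC[C@H](C)[C@H](NC(=O)N1CCC2(CC1)C(=O)N(c1cccc(F)c1)C2c1ccc(Cl)cc1)C(=O)NC`: 182 nM
- compound 3, `COC(=O)[C@H](COC(C)(C)C)NC(=O)N1CCC2(CC1)C(=O)N(c1cccc(F)c1)C2c1ccc(Cl)cc1`: 251 nM

Of the compounds shown here, three sharing one spiro-lactam core have been measured in an assay on HEK293 cells for inhibition of Voltage-dependent T-type calcium channel subunit alpha-1H (Homo sapiens), read by patch clamp, using a membrane potential dye; on this read-out lower numbers stand for stronger inhibition and higher numbers for weaker inhibition. Compound 1 gives 800 nM, compound 2 gives 182 nM and compound 3 gives 251 nM. Among these, compound 3 stands second highest: its nearest neighbour is compound 2, the step of a 1.4-fold higher number from compound 2 to compound 3 (0.14 log units; within the scatter) lying within the scatter, while compound 1 sits furthest away with a higher number beyond the scatter.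

Compound 4, `COC(=O)[C@H](CO)NC(=O)N1CCC2(CC1)C(=O)N(c1cccc(F)c1)C2c1ccc(Cl)cc1`, has not been measured. It differs from compound 3 in one place: hydrogen in place of tert-butyl on an oxygen on a saturated carbon. Going by the values given here, no measured step touches this oxygen directly. Among the compounds with values here, the only single-point step in the set, a 1.4-fold higher number from compound 2 to compound 3 (0.14 log units; within the scatter), exchanges the whole side chain on the urea nitrogen and changes little, which suggests that this region tolerates variation, but it says nothing specific about the tert-butyl group itself. Within the data shown here, with no guiding step, compound 4 is expected to land near compound 3, the estimated step of a 1.6-fold higher number from compound 3 to compound 4 (0.20 log units; within the scatter) being small and possibly within the scatter, with a wide range to reflect the lack of a precedent. Compound 4 is therefore estimated at 400 nM, between 150 nM and 1200 nM.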

Compound 4, half-maximal inhibitory concentration: 3330 nM
Estimate against measurement, compound 4: 8.3-fold (0.92 log units) below, and the stated range ends below it.
By their numbers in this assay, from the lowest: compounds 2 and 3 (each within the scatter of the next); then compound 1; then compound 4.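

In this assay, the tert-butyl on this oxygen proves to matter: hydrogen in its place gives a 13-fold higher number from compound 3 to compound 4 (1.12 log units; beyond the scatter) and so opens a large gap where the earlier compounds had shown none. The exchange of one whole side chain for another on the amide-type nitrogen had stayed small in a 1.4-fold higher number from compound 2 to compound 3 (0.14 log units; within the scatter) but not in an 18-fold higher number from compound 2 to compound 4 (1.26 log units; beyond the scatter), so the tolerance suggested by the first of these steps does not hold for every side chain at this position, and compound 4 is the one that goes against it. The data shown offer nothing that would account for this loss.

The compounds shown leave open whether the free hydroxy group or the loss of the tert-butyl carbons decides the outcome, and a methyl ether or an ethyl ether on the same oxygen would help to tell these two apart. As far as these compounds go, it also remains open whether the same step would appear with a carboxylic acid or a methylamide in place of the methyl ester on the hydroxymethyl side chain.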